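A few compounds are considered here, and "the series" means these few. Any claim that something is new, unique, unknown or untested is made for them only; others in the source may bear on it.

Compound 1 `COc1cc(OC)cc(-c2cccc(NC(=O)CCc3ccc4c(c3)B(O)OC4)c2)c1`: > 100000 nM, a limit
Compound 2 `COc1cccc(-c2cccc(NC(=O)CCc3ccc4c(c3)COB4O)c2)c1`: > 100000 nM, a limit

In an ADME assay on WI-38 cells (Homo sapiens) for cytotoxicity, read by MTT assay, with a stated time of 72 h (on this read-out lower numbers stand for stronger inhibition and higher numbers for weaker inhibition), compound 2 stands only at a limit, > 100000 nM. For the measured compounds named here, the data so far amount to the limit of > 100000 nM in this assay, at which 2 of the 2 values shown sit, so no compound can be ranked against another. Compound 3 `COc1cc(OC)cc(-c2cccc(NC(=O)CCc3ccc4c(c3)COB4O)c2)c1` differs from compound 2 by one change, methoxy in place of hydrogen on an aromatic carbon, which turns 3-methoxyphenyl into 3,5-dimethoxyphenyl. No measured step sizes this change. The expected a number no higher from compound 2 to compound 3 (the limit leaves the size open) in this assay is none beyond the scatter, in either direction, and a further limit is the likeliest report. Compound 3 is estimated at 100000 nM, with an expected range of 60000 nM to 200000 nM.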

Compound 3, half-maximal inhibitory concentration: > 100000 nM
Compound 3 gave a limit, no number; the forecaster's own chance of this, stated with the estimate: 90%; the middle value sits exactly at the limit.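

No step can be read from compound 2 to compound 3 or from compound 1 to compound 3, because all three compounds rest at one limit: the limit of > 100000 nM in this assay, at which 3 of the 3 values shown sit.

The compounds shown leave open how they would rank in this assay and what size either change has.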